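The source may report more compounds than this note shows. Statements on the series, on what has been measured and on what is new or still open speak of the compounds shown alone.

Measured so far:
- compound 1 `CC(=O)O[C@@H]1[C@H](OC(C)=O)[C@@H](CN=[N+]=[N-])O[C@H]1n1cnc2c(N)nc(F)nc21`: 18000 nM
- compound 2 `CC(=O)O[C@@H]1[C@H](OC(C)=O)[C@@H](CN=[N+]=[N-])O[C@H]1n1cnc2c(N)nc(Cl)nc21`: 141000 nM
- compound 3 `CC(=O)O[C@@H]1[C@H](OC(C)=O)[C@@H](CN2C(=O)c3ccccc3C2=O)O[C@H]1n1cnc2c(N)nc(F)nc21`: 129000 nM

All three values come from an ADME assay on L6 cells (Rattus norvegicus) for inhibition, read by resazurin assay, with a stated time of 72 h; a higher number here means a weaker inhibitor, a lower number a stronger inhibitor. Compound 2 and compound 3 cannot be separated, as their values lie within the scatter of each other. The gap on the other side is a 7.8-fold higher number from compound 1 to compound 2 (0.89 log units; beyond the scatter), for chloro in place of fluoro.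

Next in this assay is compound 4 `CC(=O)O[C@@H]1[C@H](OC(C)=O)[C@@H](CI)O[C@H]1n1cnc2c(N)nc(Cl)nc21`. The change is iodo in place of azido on a saturated chain carbon bound to a saturated ring carbon, in words iodo in place of azido on a saturated chain carbon bound to a saturated ring carbon.

Going by the values given here, only one measured step touches that place: a 7.2-fold higher number from compound 1 to compound 3 (0.86 log units; beyond the scatter), where a ring-bearing group replaces azido. Among the compounds with values here, that entering group has little in common with iodo, and no measured compound carries iodo, so the step gives only weak guidance. On these data alone, the direction stays open, and no shift beyond the scatter is firmly expected. The expected change is a 1.4-fold lower number from compound 2 to compound 4 (0.15 log units; within the scatter). For compound 4 the estimate is 100000 nM, with an expected range of 25000 nM to 300000 nM.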

Compound 4, half-maximal inhibitory concentration: 86000 nM
Estimate against measurement, compound 4: 1.2-fold (0.07 log units) above, and the stated range covers the measured number.
By their numbers in this assay, from the lowest: compound 1; then compounds 4, 3 and 2 (each within the scatter of the next).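

In this assay, iodo in place of azido on a saturated chain carbon bound to a saturated ring carbon gives a 1.6-fold lower number from compound 2 to compound 4 (0.21 log units; within the scatter), so azidomethyl to iodomethyl produces no shift that can be separated from the scatter in the chloro compounds. Going by these compounds alone, the only earlier step at this place, a 7.2-fold higher number from compound 1 to compound 3 (0.86 log units; beyond the scatter), brought in a ring-bearing group with fluoro on the aromatic carbon, and its size lies beyond the scatter, whereas this step with a single-atom group does not. No measurement at hand offers an explanation for this result.

Iodomethyl is shown only with chloro on the aromatic carbon, so whether the same swap reads alike with fluoro there stays open. On these data alone, how an amine, a carboxylic acid or a longer chain would read at this saturated chain carbon also remains open.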